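The compounds below may be only part of what the source reports. "The series", "measured", "known", "first", "only" and "open" are said of these compounds alone.

In a functional assay on HCT-116 cells (Homo sapiens) for inhibition, read by MTT assay, with a stated time of 72 h (on this read-out lower numbers stand for stronger inhibition and higher numbers for weaker inhibition), compound 1 (`CNC(=O)CCCCCCCn1nc(-c2cnc3[nH]ccc3c2)c2c(N)ncnc21`) gives 6760 nM and stands within the scatter of compound 3 (`Nc1ncnc2c1c(-c1cnc3[nH]ccc3c1)nn2CCCCCCC(=O)NO`) at 9860 nM in the same read-out. In this assay compound 2 (`Nc1nc2cc(-c3nn(CCC(=O)NO)c4ncnc(N)c34)ccc2o1`) gives > 100000 nM which is a limit and not a number. In compound 4 (`Nc1ncnc2c1c(-c1cnc3[nH]ccc3c1)nn2CCC(=O)NO`) hydroxycarbamoyl stands in place of 5-(methylcarbamoyl)pentyl on a saturated chain carbon, two bonds along the chain from an aromatic nitrogen (hydroxycarbamoyl in place of 5-(methylcarbamoyl)pentyl on a saturated chain carbon, two bonds along the chain from an aromatic nitrogen). Within the data shown here, the only measured step that bears on this, a 1.5-fold higher number from compound 1 to compound 3 (0.16 log units; within the scatter) with hydroxycarbamoyl entering on the longer chain, stays small, and no measured step shortens the chain. A higher number is therefore expected in this assay, an estimated 5.9-fold higher number from compound 1 to compound 4 (0.77 log units; beyond the scatter) beyond the scatter. The estimate for compound 4 is 40000 nM with an expected range from 12000 nM to 130000 nM in this read-out.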

Compound 4, half-maximal inhibitory concentration: > 150000 nM
Compound 4 gave a limit, no number; the forecaster's own chance of this, stated with the estimate: 35%; middle value at least 3.7-fold (0.57 log units) away from the limit.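

In this assay compound 4 stands at a limit, not a number: the limit of > 150000 nM in this assay, at which 1 of the 4 values shown sits.

With hydroxycarbamoyl kept and only the chain shortened, the change gives an at least 15-fold higher number from compound 3 to compound 4 (1.18 log units; beyond the scatter), and measured against the methylcarbamoyl chain it gives an at least 22-fold higher number from compound 1 to compound 4 (1.34 log units; beyond the scatter). Among these compounds, the earlier compounds showed only that the end group on the longer chain made no difference beyond the scatter, whereas these steps show that chain length at this position matters strongly in these compounds.

From the compounds shown here alone, the true size of the step stays unknown while compound 4 is a limit. Also open, going by these compounds, are chains of intermediate length and whether a carboxylic acid or an amine on the short chain behaves the same way.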